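A hydroxymethyl added to the core of compound 1

The source may hold more compounds than are shown below. What is called first, only, known or untested is meant among the compounds shown, and "the series" means these compounds.

Among the compounds with values here, compound 1 `O/N=C(/Nc1cccc(Br)c1)c1ccc2occc2c1` gives 440 nM in an assay on isolated protein for inhibition of Indoleamine 2,3-dioxygenase 1 (Homo sapiens), read by spectrophotometry (a lower number here means a stronger inhibitor, a higher number a weaker inhibitor), the only actual number among the two values shown. Compound 2 `CCCCOc1cccc(N/C(=N/O)c2ccc3occc3c2)c1` reaches only the limit of > 30000 nM in this assay. Thus an at least 68-fold higher number from compound 1 to compound 2 (1.83 log units; beyond the scatter), a step in which compound 2 sits at the limit of > 30000 nM in this assay, at which 1 of the 2 values shown sits.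

Compound 3 `OCc1cc2cc(/C(=N\O)Nc3cccc(Br)c3)ccc2o1` differs from compound 1 by hydroxymethyl in place of hydrogen on an aromatic carbon. Within the data shown here, the one measured step, from compound 1 to compound 2, altered a group elsewhere on the molecule and not the place where the hydroxymethyl enters, so it bears only loosely on this change. Among the measured compounds shown here, with no closer measured step, a modest change is expected in this assay, in either direction. Compound 3 is therefore estimated at 500 nM, with a range from 150 nM to 2000 nM, which corresponds to an expected step of a 1.1-fold higher number from compound 1 to compound 3 (0.06 log units; within the scatter).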

Compound 3, half-maximal inhibitory concentration: 710 nM
Estimate against measurement, compound 3: 1.4-fold (0.15 log units) below; the range from low to high includes it.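

In this assay, hydroxymethyl in place of hydrogen on this aromatic carbon, next to the ring oxygen, gives a 1.6-fold higher number from compound 1 to compound 3 (0.21 log units; within the scatter), so a first substituent at this place on the core of compound 1 leaves the two compounds indistinguishable. Until now, the only variation shown was at the bromo group, and compound 2, with butoxy in its place, gives > 30000 nM, which is a limit of the assay and not a number. Nothing shown bears on why the hydroxymethyl step is this small.

As far as these compounds go, it remains open whether this place accepts other groups equally, such as an amine, a carboxylic acid or a longer chain. Also open, from the compounds shown here alone, is whether hydroxymethyl here would give a similar result if the bromo group were replaced.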